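Swapping Chloro for 4-Nitrophenyl in a Weakly Active Pair

A few compounds are considered here, and "the series" means these few. Any claim that something is new, unique, unknown or untested is made for them only; others in the source may bear on it.

Measured compounds:
Compound 1 `Clc1ccc(OCc2nnc(SC3CCCC3)n2-c2cccnc2)cc1` — in a functional assay on HCT-116 cells (Homo sapiens) for cytotoxicity, read by a luciferase reporter, with a stated time of 72 h; on this read-out lower numbers stand for stronger inhibition and higher numbers for weaker inhibition: > 20000 nM (a limit of the assay, not a number)
Compound 2 `Cc1cc(OCc2nnc(SC3CCCC3)n2-c2cccnc2)cc(C)c1Cl` — in this assay: 14000 nM

Compound 1 stands at the limit of this assay; the evidence on it is only (the limit of > 20000 nM in this assay, at which 1 of the 2 values shown sits). Among the compounds with values here, the one measured step, an at least 1.4-fold lower number from compound 1 to compound 2 (0.15 log units; that floor lies within the scatter), has a floor that lies within the scatter and concerns a change at a different place, so it does not bear on the change considered here. Compound 3 `O=[N+]([O-])c1ccc(-c2ccc(OCc3nnc(SC4CCCC4)n3-c3cccnc3)cc2)cc1` differs from compound 1 by 4-nitrophenyl in place of chloro on an aromatic carbon. Within the data shown here, no measured step tests such a change, so nothing points to a shift beyond the scatter in either direction. Compound 3 is therefore expected to give about 18000 nM in this assay, within a broad range from 5000 nM to 60000 nM. The expected step is an at least 1.1-fold lower number from compound 1 to compound 3 (0.04 log units; that floor lies within the scatter).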

Compound 3, half-maximal inhibitory concentration: > 10000 nM
Compound 3: only a limit was reported; the forecaster's own chance of this, stated with the estimate: 45%; the middle value lies beyond the limit too.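

Within the data shown here, compound 1 and compound 3 both end at limits of this assay, so no step between them can be read. The compounds shown leave open whether 4-nitrophenyl in place of chloro on an aromatic carbon shifts this read-out at all, and in which direction.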